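The source may hold more compounds than are shown below. What is called first, only, known or untested is meant among the compounds shown, and "the series" means these compounds.

Compound 1 `CCC1C(=O)N(C)c2cnc(-n3ccc4cc(C(N)=O)ccc43)nc2N1c1ccn(C)n1` carries a primary carboxamide, and in a functional assay on K562 cells (Homo sapiens) for antiproliferative activity, read by CCK-8 assay, with a stated time of 72 h (on this read-out lower numbers stand for stronger inhibition of growth and higher numbers for weaker inhibition of growth), compound 1 gives 31300 nM, the highest of the three numbers recorded here. The two neighbours in the set sit far below it: compound 2 `CCCNC(=O)c1ccc2c(ccn2-c2ncc3c(n2)N(C2CCCC2)[C@H](CC)C(=O)N3C)c1` gives 395 nM in this assay, and compound 3 `CCCCNS(=O)(=O)c1ccc(Nc2ncc3c(n2)N(C2CCCC2)[C@H](CC)C(=O)N3C)cc1` gives 412 nM, both separated from compound 1 by gaps well beyond the usual scatter. Neither of these pairs differs from compound 1 in a single place, so the numbers speak only of the compounds as wholes.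

Compound 4 `CCC1C(=O)N(C)c2cnc(-n3ccc4cc(C(=O)NC5CCCC5)ccc43)nc2N1c1ccn(C)n1` is the unmeasured partner of compound 1. The change is cyclopentyl in place of hydrogen on an amide-type nitrogen. Among the measured compounds shown here, compound 2 shows that a substituted carboxamide can sit in a potent compound, but its other differences from compound 1 keep that from being a direct guide, and no measured step of this exact kind exists in the set. The step from compound 1 to compound 4 is therefore expected to be moderate and toward stronger inhibition, a 2.6-fold lower number from compound 1 to compound 4 (0.42 log units; beyond the scatter), without certainty that it clears the scatter. Compound 4 is accordingly estimated at 12000 nM in this assay, within a range of 3000 nM to 40000 nM.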

Compound 4, concentration for 50% growth inhibition: 31300 nM
Compound 4: the middle estimate sits 2.6-fold (0.42 log units) below what was measured; the range from low to high includes it.
By their numbers in this assay, from the lowest: compounds 2 and 3 (each within the scatter of the next); then compounds 1 and 4 (each within the scatter of the next).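

In this assay the step reads no change at the digits printed from compound 1 to compound 4 (within the scatter), so on the core of compound 1 the hydrogen on the amide-type nitrogen and a cyclopentyl there cannot be told apart by this read-out. Among the compounds shown here, the earlier compounds offered no step of this kind, since none of them differed from another in a single place; this pair is the first direct reading of the position, and it shows that a carbon-only ring can be carried on this nitrogen with no difference in the number. It also shows that this one change does not, on this core, bring the number any closer to the much lower values seen elsewhere in the set, although those compounds differ in more than one place and say nothing about the step itself. No measurement in hand explains this result.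

What the compounds shown leave open is whether an open chain such as butyl, a ring carrying an amine or a carboxylic acid, or a phenyl on the same nitrogen would read any differently. They also leave open whether cyclopentyl in this place would give the same reading on a different core.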